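Cyclic sulfonamides: cytotoxicity notes on the benzyl variants

The compounds below may be only part of what the source reports. "The series", "measured", "known", "first", "only" and "open" are said of these compounds alone.

Measured so far:
compound 1 `O=C1c2ccccc2N(Cc2ccccc2)S(=O)(=O)N1Cc1ccccc1`, 66000 nM
compound 2 `O=C1c2ccccc2N(Cc2ccccc2Cl)S(=O)(=O)N1Cc1ccccc1`, 60000 nM

Among the compounds with values here, in a functional assay on MRC5 cells (Homo sapiens) (a lower number here means that less compound is tolerated, a higher number that more compound is tolerated), compound 2 gives 60000 nM, and its one neighbour, compound 1, gives 66000 nM; the two lie within the scatter of each other, as the step of a 1.1-fold lower number from compound 1 to compound 2 (0.04 log units; within the scatter) shows. Compound 3 `O=C1c2ccccc2N(Cc2cccc3ccccc23)S(=O)(=O)N1Cc1ccccc1` differs from compound 2 by naphthalen-1-yl in place of 2-chlorophenyl on a saturated chain carbon bound to a sulfonamide nitrogen in a ring. Within the data shown here, the only step that bears on this is the one from compound 1 to compound 2, which stayed within the scatter, so only a modest change in this assay is expected, tentatively towards a lower number, as a 1.3-fold lower number from compound 2 to compound 3 (0.12 log units; within the scatter). Compound 3 is therefore estimated at 45000 nM, within the range 20000 nM to 100000 nM.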

Compound 3, half-maximal cytotoxic concentration: > 58000 nM
Compound 3: a limit, no number (the forecaster's own chance of this, stated with the estimate: 15%); middle value at least 1.2-fold (0.11 log units) from the limit.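

In this assay compound 3 gives > 58000 nM which is a limit and not a number, so the steps to it from compound 1 and compound 2 cannot be read. The compounds shown leave open how far naphthalen-1-yl in place of phenyl or 2-chlorophenyl moves the half-maximal cytotoxic concentration.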